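Cytotoxicity of a cyclopropene nucleoside pair and its thioether analogue

A few compounds are considered here, and "the series" means these few. Any claim that something is new, unique, unknown or untested is made for them only; others in the source may bear on it.

Compounds measured so far:
compound 1 `Nc1nc(NCc2ccccc2)c2ncn(/C=C3/CC3(CO)CO)c2n1` gives 19900 nM
compound 2 `CCCCNc1nc(N)nc2c1ncn2/C=C1/CC1(CO)CO` gives a limit, > 20000 nM

In an ADME assay on BCBL1 cells (Homo sapiens) for cytotoxicity, with a stated time of 7 days (a lower number here means that less compound is tolerated, a higher number that more compound is tolerated), compound 1 gives 19900 nM. For compound 2 the result is only a limit of the assay, > 20000 nM. The step between them is a number no lower from compound 1 to compound 2 (the limit leaves the size open), so all that can be said is that compound 2 is tolerated at the top of what was tested, as the limit of > 20000 nM in this assay, at which 1 of the 2 values shown sits, shows.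

Compound 3 `Nc1nc(SCc2ccccc2)c2ncn(/C=C3/CC3(CO)CO)c2n1` differs from compound 2 in one place: benzylsulfanyl in place of butylamino on an aromatic carbon. Among the compounds with values here, no measured step exchanges nitrogen for sulfur here; the only step known, from compound 1 to compound 2, leaves the size open. Compound 1, which also carries a benzyl group, sits at the same ceiling as compound 2, so compound 3 is expected to stay near that ceiling, a step of a number no higher from compound 2 to compound 3 (the limit leaves the size open). Compound 3 is therefore estimated at 20000 nM, between 8000 nM and 40000 nM, with a fair chance of only a limit.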

Compound 3, half-maximal cytotoxic concentration: > 20000 nM
Compound 3 gave a limit, no number; the forecaster's own chance of this, stated with the estimate: 50%; the middle value sits exactly at the limit.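

In this assay, compound 3 gives only a limit of the assay, > 20000 nM. Keeping the benzyl group and placing benzylsulfanyl instead of benzylamino on this aromatic carbon gives a number no lower from compound 1 to compound 3 (the limit leaves the size open), so a sulfur-linked group with no hydrogen-bond donor shows no sign of being less tolerated than the nitrogen-linked benzylamino group within the tested range. The size of that step and of the step between compound 2 and compound 3 cannot be read, because the results have reached a ceiling: the limit of > 20000 nM in this assay, at which 2 of the 3 values shown sit.

Going by these compounds, whether any group on this aromatic carbon, such as a morpholine ring or a longer chain like octylamino, would bring the value clearly down from that limit stays open. On these data alone, how far compound 2 and compound 3 lie beyond the limit also stays open.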